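The compounds below may be only part of what the source reports. "The series", "measured", "known", "first", "only" and "open" are said of these compounds alone.

Measured compounds:
- compound 1 `CCCN(CCC)S(=O)(=O)c1ccc(S(=O)(=O)N2CCC[C@@H](C(=O)OCC)C2)cc1`: 2300 nM
- compound 2 `CC(C)c1noc(N2CCN(C(=O)[C@@H]3CCCN(S(=O)(=O)c4ccc(S(=O)(=O)C(C)C)cc4)C3)CC2)n1`: 70 nM
- compound 3 `CCOC(=O)N1CCC[C@H](S(=O)(=O)c2ccc(S(=O)(=O)N(CC)CC)cc2)C1`: limit, > 30000 nM

In a functional assay on MIA PaCa-2 cells (Homo sapiens) for inhibition, read by MTT assay, with a stated time of 7 days (a lower number here means a stronger inhibitor, a higher number a weaker inhibitor), compound 1 gives 2300 nM, the highest of the two numbers, while compound 2 gives 70 nM, a gap well beyond the usual scatter. For compound 3 this assay reports only a limit, > 30000 nM, one of the values sitting at the limit of > 30000 nM in this assay, at which 1 of the 3 values shown sits.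

Compound 4 `CCOC(=O)[C@@H]1CCCN(S(=O)(=O)c2ccc(S(=O)(=O)N(C)C)cc2)C1` differs from compound 1 in one place: dimethylamino in place of dipropylamino on a sulfonyl sulfur. Within the data shown here, no measured pair isolates this change, so the expectation rests on compound 1 alone. A modest weakening, or no change beyond the scatter, is expected, so that the step of a 2.0-fold higher number from compound 1 to compound 4 (0.29 log units; within the scatter) is estimated to run towards a higher number. Compound 4 is therefore expected to give about 4500 nM, somewhere between 1500 nM and 15000 nM.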

Compound 4, half-maximal inhibitory concentration: 900 nM
The estimate for compound 4 lay 5.0-fold (0.70 log units) above the measured number, and the stated range ends above it.
By their numbers in this assay, from the lowest: compound 2; then compound 4; then compound 1. At a limit, above all of these: compound 3.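

On a sulfonyl sulfur whose other neighbour is an aromatic carbon, the smaller group does better in this assay: dimethylamino in place of dipropylamino gives a 2.6-fold lower number from compound 1 to compound 4 (0.41 log units; beyond the scatter). The longer propyl chains are therefore not needed at this position for activity in these cells. Nothing measured here accounts for the size or direction of this step.

Going by these compounds, it remains open whether an unsubstituted amino group or a ring amine such as morpholine on this sulfur would lower the number further.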